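Chloro to methyl on the anilide, repeated on a second core

The compounds below may be only part of what the source reports. "The series", "measured", "known", "first", "only" and "open" are said of these compounds alone.

Compound 1 `O=C1Nc2cc(Cl)c(F)cc2/C1=N/NC(=S)Nc1ccc(Cl)cc1` and compound 2 `Cc1ccc(NC(=S)N/N=C2\C(=O)Nc3cc(Cl)c(F)cc32)cc1` share one core. In a functional assay on MOLT-4 cells (Homo sapiens), with a stated time of 72 h (on this read-out lower numbers stand for stronger inhibition and higher numbers for weaker inhibition), compound 1 gives 43000 nM, and compound 2 gives 112000 nM. The change between them is methyl in place of chloro on an aromatic carbon, and it made a step of a 2.6-fold higher number from compound 1 to compound 2 (0.42 log units; beyond the scatter).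

Compound 3 `O=C1/C(=N\NC(=S)Nc2ccc(Cl)cc2)c2cc(Br)ccc2N1Cc1ccc(F)cc1` rests on a different core; the difference between the two cores is not broken down here. In this assay compound 3 gives 48000 nM. Compound 4 `Cc1ccc(NC(=S)N/N=C2\C(=O)N(Cc3ccc(F)cc3)c3ccc(Br)cc32)cc1` is not yet measured and differs from compound 3 by methyl in place of chloro on an aromatic carbon, the same change seen between compound 1 and compound 2, at the same kind of place.

Within the data shown here, the step from compound 3 to compound 4 is expected to be a 2.5-fold higher number from compound 3 to compound 4 (0.40 log units; beyond the scatter), because the one earlier example of this change gave a 2.6-fold higher number from compound 1 to compound 2 (0.42 log units; beyond the scatter). On that single example, compound 4 is estimated at 120000 nM, with a range from 50000 nM to 300000 nM.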

Compound 4, half-maximal inhibitory concentration: 57000 nM
Beside the measured number, compound 4's estimate is 2.1-fold (0.32 log units) above it; measured number inside the range.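

On the core of compound 3, methyl in place of chloro gives a 1.2-fold higher number from compound 3 to compound 4 (0.07 log units; within the scatter) in this assay, so on this core the swap has no effect that can be told from ordinary repeat variation. Set beside the earlier step, the two results cannot be told apart either: the same change on two cores in this assay, a 2.6-fold higher number (0.42 log units; beyond the scatter) from compound 1 to compound 2 and a 1.2-fold higher number (0.07 log units; within the scatter) from compound 3 to compound 4, 2.2-fold (0.34 log units) apart, within the scatter of two such steps

This fits a change that carries over from one core to the other, but it does not prove that, since two pairs are too few and only the first step clears the scatter. The compounds shown carry only chloro or methyl at this place, so what a methoxy group or an amine would do there remains open. Going by these compounds, whether a larger step would appear on either core with such groups also remains open.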